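This account rests on a few compounds, and the source may have more. Where it says the series, first, only, none or still open, it means among the compounds named here.

Compound 1 `C/C(=C1/OC(=O)NC1=O)C(c1ccc(-c2ccc3cccc(F)c3c2)[nH]c1=O)C(C)C` was examined in an ADME assay on microsomes from liver (Homo sapiens) for metabolic stability; on this read-out higher numbers stand for a longer-lived compound and lower numbers for a shorter-lived compound. In this assay compound 1 reached the limit of the measurement, reported as > 3 h, so only a bound is known for it rather than a number. Compound 2 `CC(C)/C(=C1\C(=O)NC(=O)N1C)c1ccc(-c2ccc3cccc(F)c3c2)[nH]c1=O`, a close relative, also sits at the limit in this assay, with a reading of > 3 h. Both values shown therefore rest at the limit of > 3 h in this assay, at which 2 of the 2 values shown sit, which leaves the position of compound 1 on the scale open above that bound.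

Compound 3 `CC(C)C(CC1NC(=O)NC1=O)c1ccc(-c2ccc3cccc(F)c3c2)[nH]c1=O` has not yet been measured in this assay. It differs from compound 1 by a group of 8 heavy atoms (4 carbon, 2 nitrogen, 2 oxygen; one five-membered non-aromatic ring with 2 hetero atoms) in place of a group of 9 heavy atoms (5 carbon, 1 nitrogen, 3 oxygen; one five-membered non-aromatic ring with 2 hetero atoms), on a saturated chain carbon bound to an aromatic carbon and a saturated chain carbon. Within the data shown here, with no measured step between compounds to draw on, the step is expected to be a number no higher from compound 1 to compound 3 (the limit leaves the size open), not beyond the usual scatter in either direction. Compound 3 is accordingly estimated at 3 h in this assay, within a range from 1.5 h to 6 h, with a fair chance that only a limit is again reported.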

Compound 3, half-life: 1.59 h
Compound 3: the middle estimate sits 1.9-fold (0.28 log units) above what was measured, and the stated range covers the measured number.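

In this assay, the change to (2,5-dioxoimidazolidin-4-yl)methyl, on a saturated chain carbon bound to an aromatic carbon and a saturated chain carbon, brings an at least 1.8-fold lower number from compound 1 to compound 3 (0.27 log units; that floor lies within the scatter). Compound 1 carries only a limit, so this figure is a floor and the real step may be larger. Compound 3 is the only compound shown with a number on this read-out, so a change in this one place is enough to bring a reading inside the measured range, while the other values stay at a limit: the limit of > 3 h in this assay, at which 2 of the 3 values shown sit.

The compounds shown leave open how far compound 1 lies beyond its limit, and so whether the step exceeds the usual scatter. They also leave open how a carboxylic acid, or a longer chain carrying the same ring, would read at this place.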